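The source may report more compounds than this note shows. Statements on the series, on what has been measured and on what is new or still open speak of the compounds shown alone.

- Compound 1 `CCN(CC)CCNC(=O)c1ccc(C(CC)(CC)c2ccc(OCC(=O)C(C)(C)C)c(C)c2)n1CC`: 1600 nM
- Compound 2 `CCn1c(C(=O)NCCN)ccc1C(CC)(CC)c1ccc(OCC(O)C(C)(C)C)c(C)c1`: 1000 nM
- Compound 3 `C=CCN(C)C(=O)c1ccc(C(CC)(CC)c2ccc(OCC(O)C(C)(C)C)c(C)c2)n1CC`: > 50000 nM

All three entries come from a functional assay on Caco-2 cells (Homo sapiens), read by MTT assay, with a stated time of 48 h; a lower number here means a stronger inhibitor, a higher number a weaker inhibitor. Compound 1 at 1600 nM and compound 2 at 1000 nM lie within the usual scatter of each other. Compound 3 reads > 50000 nM, which is a limit of the assay and not a number.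

Compound 4 `CC[C@@H](C)[C@H](NC(=O)c1ccc(C(CC)(CC)c2ccc(OCC(=O)C(C)(C)C)c(C)c2)n1CC)C(=O)O` keeps the core of compound 1 and makes one change: 1-carboxy-2-methylbutyl in place of 2-(diethylamino)ethyl on an amide-type nitrogen. For the measured compounds named here, only one measured step bears on this. Swapping (2-aminoethyl)amino for allyl(methyl)amino on the same carbonyl carbon gave a large loss of activity, an at least 50-fold higher number from compound 2 to compound 3 (1.69 log units; beyond the scatter). The group entering compound 4 also has no amino nitrogen, so a similar direction seems likely, although the two new groups differ and the comparison is rough. The expected change is a large rise, a 19-fold higher number from compound 1 to compound 4 (1.27 log units; beyond the scatter). For compound 4 the estimated value is 30000 nM, with an expected range of 5000 nM to 50000 nM.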

Compound 4, half-maximal inhibitory concentration: 4500 nM
Compound 4: middle estimate off by 6.7-fold (0.82 log units), on the high side; the whole stated range lies above it.
By their numbers in this assay, from the lowest: compounds 2 and 1 (each within the scatter of the next); then compound 4. At a limit, above all of these: compound 3.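

In this assay, replacing 2-(diethylamino)ethyl with 1-carboxy-2-methylbutyl on the amide-type nitrogen costs only a modest amount of activity, a 2.8-fold higher number from compound 1 to compound 4 (0.45 log units; beyond the scatter). The earlier compounds shown here all carried an amino nitrogen on this side chain or had lost activity entirely, whereas this change removes the amino nitrogen, adds a carboxylic acid, and still leaves a measurable number. Compound 3 remains the only compound at a limit, which is not a number: the limit of > 50000 nM in this assay, at which 1 of the 4 values shown sits.

Because the acid and the branched carbon chain enter together, the compounds shown leave open which of them accounts for the step. As far as these compounds go, a methyl ester of the same group, or a simple 2-methylbutyl chain on this nitrogen, would separate the two, and the role of the two defined stereocentres also remains open.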